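A few compounds are considered here, and "the series" means these few. Any claim that something is new, unique, unknown or untested is made for them only; others in the source may bear on it.

Values in a physicochemical assay for lipophilicity, using the shake flask method, in phosphate buffer, measured as octanol-water partition, with a stated time of 30 min, at pH 7.4; on this read-out higher numbers stand for higher lipophilicity and lower numbers for lower lipophilicity:
Compound 1 `Cn1cc(-c2cnc(NCc3c(F)ccc4c3CCO4)c3cn[nH]c(=O)c23)cn1`: 2.7
Compound 2 `Cc1ncccc1-c1cnc(NCc2c(F)ccc3c2CCO3)c2n[nH]c(=O)n12`: 2.5
Compound 3 `Cc1ncc(-c2cnc(NCc3c(F)ccc4c3CCO4)c3cn[nH]c(=O)c23)n1C`: 1.9

Of these three, compound 3 has the lowest number, at 1.9, and both of the others stand higher. Compound 4 `Cc1ncccc1-c1cnc(NCc2c(F)ccc3c2CCO3)c2cn[nH]c(=O)c12` has not yet been measured. It differs from compound 3 by one exchange: 2-methylpyridin-3-yl in place of 1,2-dimethyl-1H-imidazol-5-yl on an aromatic carbon. This places 2-methylpyridin-3-yl in place of 1,2-dimethyl-1H-imidazol-5-yl on an aromatic carbon of a six-membered aromatic ring with 1 nitrogen.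

Going by the values given here, one measured step bears directly on this place: a number 0.80 log units lower from compound 1 to compound 3 (beyond the scatter). There, 1,2-dimethyl-1H-imidazol-5-yl came in for 1-methyl-1H-pyrazol-4-yl, so the group now leaving is the one that went with the lower number. Among the compounds with values here, no measured step brings 2-methylpyridin-3-yl onto the core shared by compound 3 and compound 4. Within the data shown here, the only reading for that group comes from compound 2, which carries it on a different core and gives 2.5. A rise of modest size is therefore expected, close to the measured step in magnitude but opposite in direction. The expected change is a number 0.60 log units higher from compound 3 to compound 4 (beyond the scatter). The estimate for compound 4 is 2.5, with an expected range from 2.1 to 2.9.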

Compound 4, distribution coefficient: 3
Compound 4: the middle estimate sits 0.50 log units below what was measured, and the stated range ends below it.
By their numbers in this assay, from the lowest: compound 3; then compounds 2, 1 and 4 (each within the scatter of the next, the first and the last beyond it).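

In this assay, going by these compounds alone, the exchange on this aromatic carbon, para to a large group, now shows that 2-methylpyridin-3-yl in place of 1,2-dimethyl-1H-imidazol-5-yl gives a number 1.10 log units higher from compound 3 to compound 4 (beyond the scatter), a large step, whereas the one earlier step on this core was modest: a number 0.80 log units lower from compound 1 to compound 3 (beyond the scatter). Within the data shown here, the two groups exchanged have the same count of heavy atoms, so a step of this size on the shared core arises without any change in that count. 2-methylpyridin-3-yl and 1-methyl-1H-pyrazol-4-yl are not told apart on this read-out, at a number 0.30 log units higher from compound 1 to compound 4 (within the scatter), which leaves 1,2-dimethyl-1H-imidazol-5-yl in compound 3 as the one group of the three standing apart, beyond the scatter from both others.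

The compounds shown leave open how a non-aromatic group on this carbon, such as a morpholine, a primary amine or a carboxylic acid, would read in this assay, and how an unsubstituted pyridin-3-yl would compare with its methylated counterpart. Nothing available accounts for the size of the step from the imidazole group to the pyridine group.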